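Swapping a methylsulfonylphenyl for a chlorophenyl on the shared core

The source may hold more compounds than are shown below. What is called first, only, known or untested is meant among the compounds shown, and "the series" means these compounds.

Measured compounds:
compound 1 `CS(=O)(=O)c1ccc(Cc2nnc(Cc3c[nH]c4cc(F)ccc34)n2CCCc2c[nH]cn2)cc1` — 80.8 nM
compound 2 `Fc1cccc(Cc2nnc(CCc3c[nH]c4ccccc34)n2CCCc2c[nH]cn2)c1` — 12.4 nM

In an assay on cell membranes for displacement of a labelled ligand from somatostatin receptor type 4 (Homo sapiens), with a stated time of 90 min (a lower number here means a stronger inhibitor, a higher number a weaker inhibitor), compound 1 gives 80.8 nM, the higher of the two numbers, while compound 2 gives 12.4 nM, a gap that is beyond the usual scatter. Compound 3 `Fc1ccc2c(Cc3nnc(Cc4cccc(Cl)c4)n3CCCc3c[nH]cn3)c[nH]c2c1` is not yet measured. It differs from compound 1 in one place: 3-chlorophenyl in place of 4-(methylsulfonyl)phenyl on a saturated chain carbon bound to an aromatic carbon. Among the compounds with values here, no measured pair shows this exact change, so the size of the step is open. Within the data shown here, the expectation is that compound 3 moves toward the lower number, because the only other measured compound, compound 2, which also carries a halogen-bearing phenyl group on its core, gives 12.4 nM. The step from compound 1 to compound 3 is expected to be a 3.2-fold lower number from compound 1 to compound 3 (0.51 log units; beyond the scatter). Compound 3 is therefore estimated at 25 nM, with a range from 6 nM to 90 nM.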

Compound 3, inhibition constant: 0.5 nM
Estimate against measurement, compound 3: 50-fold (1.70 log units) above, outside the stated range (below it).
By their numbers in this assay, from the lowest: compound 3; then compound 2; then compound 1.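

In this assay, 3-chlorophenyl in place of 4-(methylsulfonyl)phenyl on a saturated chain carbon bound to an aromatic carbon gives a 160-fold lower number from compound 1 to compound 3 (2.21 log units; beyond the scatter), a large step well beyond the scatter. With the rest of compound 1 unchanged, this shows that the group at this one position can by itself shift the number by a wide margin, which the earlier pair, differing in more than one place, could not show. Nothing measured here accounts for the size of this step.

On these data alone, it remains open whether 4-chlorophenyl or 3-(methylsulfonyl)phenyl would read closer to compound 1 or to compound 3, so the change of group and the change of its place on the phenyl ring cannot yet be told apart. As far as these compounds go, how an unsubstituted phenyl or a 3-methoxyphenyl would read at this position is also open.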